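The source may report more compounds than this note shows. Statements on the series, on what has been measured and on what is new or still open speak of the compounds shown alone.

Compound 3 `CCC(C)/N=C(\C)c1c(O)c2ccccc2oc1=O` gives no number in an assay on isolated protein for inhibition of myosin-2 (Bos taurus), read by spectrophotometry, with a stated time of 24 min (on this read-out lower numbers stand for stronger inhibition and higher numbers for weaker inhibition), but only a limit, >= 100000 nM, one of the values that sit at the limit of >= 100000 nM in this assay, at which 1 of the 3 values shown sits. Compound 2 `CCCCCC/N=C(\C)c1c(O)c2ccccc2oc1=O` gives 2900 nM in this assay, and compound 1 `C/C(=N\Cc1ccccn1)c1c(O)c2ccccc2oc1=O` gives 22000 nM. Compound 4 `CCCCC/N=C(\C)c1c(O)c2ccccc2oc1=O` awaits measurement and differs from compound 3 in one place: pentyl in place of sec-butyl on a double-bonded nitrogen. Among the measured compounds shown here, two measured steps bear on this change. Read in reverse, an at least 34-fold higher number from compound 2 to compound 3 (1.53 log units; beyond the scatter), and an at least 4.5-fold higher number from compound 1 to compound 3 (0.65 log units; beyond the scatter). Since pentyl resembles the hexyl of compound 2 far more than the sec-butyl it replaces, compound 4 is expected to come out near compound 2. The step of an at least 25-fold lower number from compound 3 to compound 4 (1.39 log units; beyond the scatter) is therefore expected to be large, toward lower numbers. Compound 4 is estimated at 4000 nM, within a range from 1500 nM to 15000 nM.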

Compound 4, half-maximal inhibitory concentration: 6700 nM
Estimate against measurement, compound 4: 1.7-fold (0.22 log units) below; the range from low to high includes it.
By their numbers in this assay, from the lowest: compound 2; then compound 4; then compound 1. At a limit, above all of these: compound 3.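

Compound 3 stands only at a limit: the limit of >= 100000 nM in this assay, at which 1 of the 4 values shown sits. In this assay pentyl on the double-bonded nitrogen clearly beats sec-butyl, with an at least 14-fold lower number from compound 3 to compound 4 (1.17 log units; beyond the scatter), and also beats the pyridin-2-yl chain, with a 3.3-fold lower number from compound 1 to compound 4 (0.52 log units; beyond the scatter). Trimming hexyl to pentyl costs far less, with a 2.3-fold higher number from compound 2 to compound 4 (0.36 log units; beyond the scatter), so two unbranched chains both give measurable numbers here. Still open, on these data alone, is whether sec-butyl loses through its branch or through its shorter chain, which a butyl on the same nitrogen would separate. A longer chain such as heptyl would show whether lengthening keeps lowering the number.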